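The compounds below may be only part of what the source reports. "The series", "measured", "known", "first", "only" and "open" are said of these compounds alone.

Measured compounds:
- Compound 1 `CNc1nc(NC2(C#N)CCCCC2)nc(N(C)C)n1` gives > 5000 nM in an in vitro assay on Sf21 cells for inhibition of high affinity 3',5'-cyclic-AMP phosphodiesterase 7A (Homo sapiens); on this read-out higher numbers stand for weaker inhibition and lower numbers for stronger inhibition; this is a limit of the assay and not a number.
- Compound 2 `CNc1nc(NC2(C#N)CCCCC2)nc(SC)n1` gives 46 nM in this assay.

Compound 1 stands at a limit of > 5000 nM in this assay, at which 1 of the 2 values shown sits: of the two measured compounds it is the one for which only a range, not a number, is known. Among the measured compounds shown here, the only measured change is the step from compound 1 to compound 2, which shows an at least 100-fold lower number from compound 1 to compound 2 (2.03 log units; beyond the scatter).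

Compound 3 `CNc1nc(C#N)nc(NC2(C#N)CCCCC2)n1` has not yet been measured. It differs from compound 1 by cyano in place of dimethylamino on an aromatic carbon. The step to compound 2 is the one that bears on it, since there too dimethylamino left the same aromatic carbon and a small group took its place, and that step was large. Because an at least 100-fold lower number from compound 1 to compound 2 (2.03 log units; beyond the scatter) was seen when methylsulfanyl replaced dimethylamino, a large step toward lower numbers is also expected when cyano does so, although no measurement shows how cyano compares with methylsulfanyl. The step expected is an at least 25-fold lower number from compound 1 to compound 3 (1.39 log units; beyond the scatter). For compound 3 the estimate in this assay is 200 nM, with a range from 30 nM to 2000 nM.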

Compound 3, half-maximal inhibitory concentration: > 1000 nM
Compound 3 ended at the assay's limit (the forecaster's own chance of this, stated with the estimate: 15%); middle value at least 5.0-fold (0.69 log units) from the limit.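

At this aromatic carbon, opposite the ring nitrogen, the choice of the small group that replaces dimethylamino matters a great deal: cyano in place of methylsulfanyl gives an at least 21-fold higher number from compound 2 to compound 3 (1.33 log units; beyond the scatter). Losing dimethylamino is therefore not enough in itself, and among the three groups shown, the low number goes with methylsulfanyl alone. From the compounds shown here alone, compound 1 and compound 3 each stand at a limit of the assay and not at a number, so the step between them cannot be read, and whether cyano offers any gain over dimethylamino stays unknown.

The compounds shown leave open whether the sulfur atom of methylsulfanyl matters, or whether other small groups on this carbon would do as well, such as methoxy, with oxygen in place of sulfur, or a plain methyl group. They also leave open how far a longer chain on the sulfur, such as ethylsulfanyl, would keep the low number of compound 2, 46 nM.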